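A few compounds are considered here, and "the series" means these few. Any claim that something is new, unique, unknown or untested is made for them only; others in the source may bear on it.

Measured in a functional assay on ID8 cells (Mus musculus) for antiproliferative activity; a higher number here means a weaker inhibitor, a lower number a stronger inhibitor:
- Compound 1 `O=C(Nc1ccc(O)c2c(=O)cc(-c3ccccc3Cl)oc12)c1ccccc1`: 13000 nM
- Compound 2 `CS(=O)(=O)Nc1ccc(O)c2c(=O)cc(-c3ccccc3Cl)oc12`: 16000 nM
- Compound 3 `O=c1cc(-c2ccccc2Cl)oc2c(NS(=O)(=O)c3ccccc3)ccc(O)c12`: 9500 nM

In this assay, compound 3 cannot be separated from the other two: the data show a 1.4-fold lower number from compound 1 to compound 3 (0.14 log units; within the scatter) and a 1.7-fold lower number from compound 2 to compound 3 (0.23 log units; within the scatter). The remaining pair behaves the same way, with a 1.2-fold higher number from compound 1 to compound 2 (0.09 log units; within the scatter).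

Compound 4 `O=c1cc(-c2ccccc2Cl)oc2c(NS(=O)(=O)c3cc(Cl)cc(Cl)c3O)ccc(O)c12` keeps the shared core of compound 3 and changes in one place, with 3,5-dichloro-2-hydroxyphenyl in place of phenyl on a sulfonyl sulfur.

For the measured compounds named here, the closest precedent is the change at that same sulfonyl sulfur, a 1.7-fold lower number from compound 2 to compound 3 (0.23 log units; within the scatter). The swaps on the nitrogen, a 1.2-fold higher number from compound 1 to compound 2 (0.09 log units; within the scatter) and a 1.4-fold lower number from compound 1 to compound 3 (0.14 log units; within the scatter), bear on it less directly. Going by the values given here, no measured compound carries any substituent on the phenyl ring, so the size of this step is poorly constrained. A step clearly beyond the scatter is therefore not expected, though a slight lean towards a lower number is allowed.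

The expected step is a 1.5-fold lower number from compound 3 to compound 4 (0.16 log units; within the scatter).

For compound 4 the estimated value is 6500 nM, with an expected range of 2500 nM to 16000 nM.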

Compound 4, half-maximal inhibitory concentration: 24000 nM
For compound 4 the middle estimate is 3.7-fold (0.57 log units) below the measured one; the whole stated range lies below it.
By their numbers in this assay, from the lowest: compounds 3, 1, 2 and 4 (each within the scatter of the next, the first and the last beyond it).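

In this assay, for the compounds shown here, the sulfonyl sulfur gives the only step in this set that lies beyond the scatter: 3,5-dichloro-2-hydroxyphenyl in place of phenyl gives a 2.5-fold higher number from compound 3 to compound 4 (0.40 log units; beyond the scatter), and the change is towards a weaker inhibitor. Swaps among benzoyl, methylsulfonyl and phenylsulfonyl had not separated any compounds, so this shows that substituents on the phenyl ring at this position can shift the number. Set against methyl on the same sulfur, the new group gives a 1.5-fold higher number from compound 2 to compound 4 (0.18 log units; within the scatter), so it separates from phenyl but not from methyl.

No supporting measurement is available to explain this step. The change brings in hydroxyl and chlorine together, so the compounds shown leave open what a phenyl ring bearing only chlorine, only hydroxyl, or an amine would give.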